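A few compounds are considered here, and "the series" means these few. Any claim that something is new, unique, unknown or untested is made for them only; others in the source may bear on it.

Of the compounds shown here, three built on one shared core have so far been measured in a functional assay on K562 cells (Homo sapiens) for inhibition, read by MTT assay, with a stated time of 72 h; a lower number here means a stronger inhibitor, a higher number a weaker inhibitor. Compound 1 `O=C1C[C@H]2O[C@H](C(O)O)[C@H](O)[C@H]2O1` gives 28 nM, compound 2 `O=C1C[C@H]2O[C@H]([C@H](O)c3ccccc3)[C@H](O)[C@H]2O1` gives 410 nM, and compound 3 `CO[C@@H]1[C@H]2OC(=O)C[C@H]2O[C@@H]1[C@H](O)c1ccccc1` gives 5360 nM. Compound 2 therefore stands second highest of the three numbers; its nearest neighbour is compound 3, and compound 1 lies furthest from it. The unmeasured compound 4 `CO[C@H](c1ccccc1)[C@H]1O[C@@H]2CC(=O)O[C@@H]2[C@H]1O` differs from compound 2 by methyl in place of hydrogen on an oxygen on a saturated carbon. Among the measured compounds shown here, one measured step bears directly on this: the same kind of change, a methyl in place of hydrogen on an oxygen on a saturated carbon, but on a different oxygen of the core, gave a 13-fold higher number from compound 2 to compound 3 (1.12 log units; beyond the scatter). That step points towards a higher number for compound 4 as well, although the oxygen that carries the new methyl is not the same one, so the size is less certain. A step of about a 4.9-fold higher number from compound 2 to compound 4 (0.69 log units; beyond the scatter) is therefore expected. Compound 4 is estimated to give 2000 nM, with a range from 500 nM to 8000 nM.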

Compound 4, half-maximal inhibitory concentration: 7950 nM
Estimate against measurement, compound 4: 4.0-fold (0.60 log units) below, and the stated range covers the measured number.
By their numbers in this assay, from the lowest: compound 1; then compound 2; then compounds 3 and 4 (each within the scatter of the next).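

Changing hydroxy to methoxy at this oxygen gives a 19-fold higher number from compound 2 to compound 4 (1.29 log units; beyond the scatter) in this assay, so this is a large loss of inhibition from a single added carbon. Set beside a 13-fold higher number from compound 2 to compound 3 (1.12 log units; beyond the scatter), it shows that the same methyl in place of hydrogen raises the number beyond the scatter on both of the oxygens tested, not on just one of them. Nothing presented here explains this shared effect.

On these data alone, it remains open whether a longer chain such as ethyl, or an acetyl group, on this oxygen would behave as methyl does. An amine in place of the hydroxy, or a fluorine, would also test whether any replacement of this group can keep the number of compound 2 at 410 nM.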